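Shrinking a Ring: Compound 3 to Compound 4

This account rests on a few compounds, and the source may have more. Where it says the series, first, only, none or still open, it means among the compounds named here.

Of the compounds shown here, three of a shared core have been measured in an ADME assay on MT4 cells (Homo sapiens) for cytotoxicity, read by MTT assay; a higher number here means that more compound is tolerated, a lower number that less compound is tolerated. Compound 1 `Cc1cnc(Nc2ccc(C#N)cc2)nc1NC1CC1` gives 360 nM. Compound 2 `N#Cc1ccc(Nc2nccc(SC3CCCCC3)n2)cc1` gives only a limit of the assay, > 402000 nM, not a number (the limit of > 402000 nM in this assay, at which 1 of the 3 values shown sits). Compound 3 `N#Cc1ccc(Nc2nccc(NC3CCCC3)n2)cc1` gives 9130 nM, the highest of the two numbers, with compound 1 the nearest and lower. One step connects measured compounds: an at least 44-fold lower number from compound 2 to compound 3 (1.64 log units; beyond the scatter).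

Compound 4 `N#Cc1ccc(Nc2nccc(NC3CC3)n2)cc1` is not yet measured. It differs from compound 3 in one place: cyclopropyl in place of cyclopentyl on a nitrogen on an aromatic ring. Among the measured compounds shown here, the one measured step, from a sulfur-linked ring to a nitrogen-linked one, does not touch ring size, so no measured step speaks directly to this change. For the measured compounds named here, the only guidance is that compound 1, which also carries a cyclopropylamino group on a related core, gives 360 nM, a lower number than compound 3. A move toward that value seems plausible, though the cores are not the same.

The expectation is therefore a moderate decrease, with compound 4 estimated at 3000 nM, within 800 nM to 15000 nM, meaning an expected step of a 3.0-fold lower number from compound 3 to compound 4 (0.48 log units; beyond the scatter).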

Compound 4, half-maximal cytotoxic concentration: 1190 nM
Estimate against measurement, compound 4: 2.5-fold (0.40 log units) above; the range from low to high includes it.
By their numbers in this assay, from the lowest: compound 1; then compound 4; then compound 3. At a limit, above all of these: compound 2.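

In this assay, ring size on the nitrogen now has a measured step of its own (a 7.7-fold lower number from compound 3 to compound 4 (0.88 log units; beyond the scatter)), with cyclopropyl in place of cyclopentyl and everything else unchanged. Compound 1 can now also be read against a true partner, since hydrogen in place of methyl on an aromatic carbon is the only difference (a 3.3-fold higher number from compound 1 to compound 4 (0.52 log units; beyond the scatter)), so the cyclopropylamino group no longer has to be compared across two differing structures. Compound 2 sits at a limit and not at a number, so its step (an at least 330-fold lower number from compound 2 to compound 4 (2.52 log units; beyond the scatter)) changes the linking atom and the ring size at once and gives only a bound: the limit of > 402000 nM in this assay, at which 1 of the 4 values shown sits.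

The compounds shown cover only two ring sizes on the nitrogen of this shared core, so a cyclobutyl ring or an open chain such as isopropyl would be needed to tell whether the number follows ring size at all. A cyclohexylamino group would separate the effect of the ring from that of the linking atom, and nothing shown tells why the numbers move.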